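This account rests on a few compounds, and the source may have more. Where it says the series, first, only, none or still open, it means among the compounds named here.

Compound 1 `COc1ccc(/C=C/C(=O)c2c(O)cc(C)oc2=O)cc1`: > 100000 nM
Compound 2 `Cc1cc(O)c(C(=O)/C=C/c2ccc(N(C)C)cc2)c(=O)o1`: > 100000 nM

In a functional assay on HCT-116 cells (Homo sapiens) for cytotoxicity, read by MTT assay (on this read-out higher numbers stand for weaker inhibition and lower numbers for stronger inhibition), compound 2 gives > 100000 nM, which is a limit of the assay and not a number. Compound 1 gives > 100000 nM, which is also a limit. Among the measured compounds shown here, compound 2 therefore shares its position with the only other measured compound: the limit of > 100000 nM in this assay, at which 2 of the 2 values shown sit.

Compound 3 `Cc1cc(O)c(C(=O)/C=C/c2ccc([N+](=O)[O-])cc2)c(=O)o1` keeps the core of compound 2 but carries nitro in place of dimethylamino on an aromatic carbon, para to a large group: nitro in place of dimethylamino on an aromatic carbon.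

For the measured compounds named here, only one measured step bears on this change, and it concerns the same ring carbon: a step that the two limits leave unreadable from compound 1 to compound 2. That step offers no size to carry over, so the data give no sign that exchanging this group moves the read-out in this assay. No clear gain in strength is expected, and compound 3 may well be reported only as a limit too. The expected change is a number no higher from compound 2 to compound 3 (the limit leaves the size open), with no direction that can be firmly stated. The estimate for compound 3 is 100000 nM, with an expected range from 30000 nM to 200000 nM.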

Compound 3, half-maximal inhibitory concentration: 65000 nM
The estimate for compound 3 lay 1.5-fold (0.19 log units) above the measured number; measured number inside the range.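

In this assay compound 3 gives 65000 nM, the only actual number among the three compounds shown, so a group on this ring carbon can bring the read-out into the measurable range. Nitro in place of dimethylamino gives an at least 1.5-fold lower number from compound 2 to compound 3 (0.18 log units; that floor lies within the scatter), and nitro in place of methoxy gives an at least 1.5-fold lower number from compound 1 to compound 3 (0.18 log units; that floor lies within the scatter); these are only floors, so the true gaps may be larger, but the data firmly show no more than a difference that cannot yet be told from the scatter. Compound 1 and compound 2 remain without a number, which is what sets these floors: the limit of > 100000 nM in this assay, at which 2 of the 3 values shown sit.

As far as these compounds go, how far the values of compound 1 and compound 2 lie past their shared limit stays unknown, so the true size of both steps remains open, and the step between those two compounds cannot be read. Also open, from the compounds shown here alone, is whether the measurable value is tied to nitro or would also appear with another group on the same ring carbon, such as a carboxylic acid or a chlorine atom.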